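The source may hold more compounds than are shown below. What is called first, only, known or untested is meant among the compounds shown, and "the series" means these compounds.

Measured in a physicochemical assay for metabolic stability, read by HPLC, in phosphate buffer, at pH 7.4; a lower number here means that the compound disappears faster, a higher number that the compound lasts longer:
- compound 1 `CN(/N=N/c1ccc(C#N)cc1)C(=O)CCc1ccc(O)cc1`: 76 h
- compound 2 `CN(/N=N/c1ccc(C(N)=O)cc1)C(=O)CCc1ccc(O)cc1`: 118 h
- compound 3 `CN(/N=N/c1ccc(C(N)=O)cc1)C(=O)CCCCc1ccc(O)cc1`: 182 h

Compound 2, at 118 h, stands in the middle of these three numbers, and its value lies within the scatter of the values of both compound 1 and compound 3. Compound 4 `CC(=O)c1ccc(/N=N/N(C)C(=O)CCc2ccc(O)cc2)cc1` has not yet been measured in this assay. Its structure departs from that of compound 2 in one place: methyl in place of amino on a carbonyl carbon. Put another way, compound 2 carries carbamoyl where compound 4 carries acetyl.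

For the measured compounds named here, only one measured step involves this group, the exchange of cyano for carbamoyl on an aromatic carbon: a 1.6-fold higher number from compound 1 to compound 2 (0.19 log units; within the scatter). That step stayed within the scatter. Compound 3 differs from compound 2 elsewhere in the structure, so it does not bear on this change. Going by the values given here, no compound with an acetyl group has been measured, which leaves this single step as a weak guide. No change beyond the scatter is therefore expected, and the estimated step is a 1.2-fold lower number from compound 2 to compound 4 (0.09 log units; within the scatter). For compound 4 the expected half-life is 95 h, with an estimated range of 50 h to 180 h.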

Compound 4, half-life: 123 h
Beside the measured number, compound 4's estimate is 1.3-fold (0.11 log units) below it; the measured number falls inside the stated range.
By their numbers in this assay, from the lowest: compounds 1, 2, 4 and 3 (each within the scatter of the next, the first and the last beyond it).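

In this assay, methyl in place of amino on a carbonyl carbon, which turns carbamoyl into acetyl, gives a 1.0-fold higher number from compound 2 to compound 4 (0.02 log units; within the scatter) and acetyl in place of cyano on an aromatic carbon gives a 1.6-fold higher number from compound 1 to compound 4 (0.21 log units; within the scatter) as the second step at this place. The earlier compounds shown here offered only the exchange of cyano for carbamoyl here, whereas the three groups cyano, carbamoyl and acetyl now all lie within the scatter of one another, and the amino group with its hydrogen-bond donor can leave the carbonyl carbon with no change beyond the scatter in this half-life. Nothing at hand accounts for this result. On these data alone, it remains open whether a group of another kind on this aromatic carbon, such as a carboxylic acid, an amine or a trifluoromethyl, would carry the half-life beyond the scatter, or whether all such groups would stay within it as these three do. Also open, as far as these compounds go, is whether acetyl in place of carbamoyl would read the same on the longer chain that compound 3 carries.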